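The source may hold more compounds than are shown below. What is called first, only, known or untested is meant among the compounds shown, and "the series" means these compounds.

Measured so far:
- compound 1, `COc1ccc2nc(-c3c(Cl)nc(N)nc3N[C@@H]3C[C@H](CO)[C@@H](O)[C@H]3O)sc2c1`
- compound 2, `CCNc1nc(C)c(-c2nc3ccccc3s2)c(N[C@@H]2C[C@H](CO)[C@@H](O)[C@H]2O)n1`

For the measured compounds named here, in an ADME assay on cells (Homo sapiens) for cytotoxicity, read by polymerase chain reaction, with a stated time of 3 days (on this read-out lower numbers stand for higher toxicity in this test and higher numbers for lower toxicity in this test), compound 2 gives 12000 nM, the only actual number in the set. For compound 1 the read-out is a limit of the test, > 25000 nM, as recorded in the limit of > 25000 nM in this assay, at which 1 of the 2 values shown sits. Compound 3, `COCCNc1nc(C)c(-c2nc3ccccc3s2)c(N[C@@H]2C[C@H](CO)[C@@H](O)[C@H]2O)n1`, carries methoxy in place of hydrogen on a saturated chain carbon, two bonds along the chain from a nitrogen on an aromatic ring. Going by the values given here, no measured step of this kind exists here, so the only guide is the value of compound 2. The change is expected to shift the read-out little, if at all, beyond the usual scatter. Compound 3 is expected to give 15000 nM, within 6000 nM to 40000 nM, with a 1.3-fold higher number from compound 2 to compound 3 (0.10 log units; within the scatter) expected to lie near nil.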

Compound 3, half-maximal cytotoxic concentration: 21000 nM
Compound 3: the middle estimate sits 1.4-fold (0.15 log units) below what was measured, within the range that was stated.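

Working from the one step at this position, a 1.8-fold higher number from compound 2 to compound 3 (0.24 log units; within the scatter) in this assay, methoxy on this saturated chain carbon, which turns ethylamino into (2-methoxyethyl)amino, gives no difference that can be told from the scatter. Like compound 2, compound 3 reads as a number, so this pair can be compared directly. Compound 1 differs from both in more than one place and stands at a limit of the test: the limit of > 25000 nM in this assay, at which 1 of the 3 values shown sits.

On these data alone, whether a longer chain, a terminal amine or a carboxylic acid at this place would move the read-out beyond the scatter remains open. A single step also leaves open whether methoxy would behave alike on another core.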